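The compounds below may be only part of what the source reports. "The series", "measured", "known", "first", "only" and "open" are said of these compounds alone.

Measured compounds:
compound 1 `[N-]=[N+]=NC[C@H]1O[C@H](CO)[C@@H](O)[C@H](O)[C@H]1O` gives 25100000 nM in an assay on isolated protein (Sus scrofa) for inhibition of glycogen phosphorylase, brain form (Homo sapiens); on this read-out higher numbers stand for weaker inhibition and lower numbers for stronger inhibition
compound 2 `OC[C@H]1O[C@@](O)(CO)[C@H](O)[C@@H](O)[C@@H]1O` gives 15800000 nM in this assay
compound 3 `NC[C@H]1O[C@H](CO)[C@@H](O)[C@H](O)[C@H]1O` gives 31600000 nM in this assay

Compound 2 has the lowest of the three numbers, yet its gaps to compound 1 and compound 3 both lie within the scatter, so none of the three can be set apart from the others. Compound 4 `N#CC[C@]1(O)O[C@H](CO)[C@@H](O)[C@H](O)[C@H]1O` differs from compound 2 by cyano in place of hydroxy on a saturated chain carbon bound to a saturated ring carbon. For the measured compounds named here, only one measured step touches a group at that place: a 1.3-fold higher number from compound 1 to compound 3 (0.10 log units; within the scatter), which stayed within the scatter. That step swaps different groups, so it is a weak guide, but it is the only one. On this basis the step from compound 2 to compound 4 is expected to be a 1.1-fold lower number from compound 2 to compound 4 (0.02 log units; within the scatter), that is, no change beyond the scatter. Compound 4 is therefore estimated at 15000000 nM, with a range from 5000000 nM to 50000000 nM.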

Compound 4, inhibition constant: 7940000 nM
Estimate against measurement, compound 4: 1.9-fold (0.28 log units) above, within the range that was stated.
By their numbers in this assay, from the lowest: compounds 4, 2, 1 and 3 (each within the scatter of the next, the first and the last beyond it).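

In this assay, cyano in place of hydroxy on a saturated chain carbon bound to a saturated ring carbon gives a 2.0-fold lower number from compound 2 to compound 4 (0.30 log units; within the scatter), so the two compounds cannot be told apart. At this place, then, replacing hydroxy with cyano removes a hydrogen-bond donor and adds a heavy atom without a difference beyond the scatter. No available evidence bears on this result.

As far as these compounds go, whether a carboxylic acid, an amide or a longer chain at this place would give a number beyond the scatter from compound 2 remains open.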